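Dithiocarbamate thioester series: working notes toward compound 4

The source may hold more compounds than are shown below. What is called first, only, known or untested is meant among the compounds shown, and "the series" means these compounds.

Measured so far:
compound 1, `CC1CCCN(C(=S)SC(=S)N(C)C)C1`: in an ADME assay on HeLa cells (Homo sapiens) for cytotoxicity, read by MTT assay, with a stated time of 24 h (on this read-out lower numbers stand for stronger inhibition and higher numbers for weaker inhibition), compound 1 gives 2900000 nM.
compound 2, `CCCCN1CCN(C(=S)SC(=S)N(C)C)CC1`: in this assay compound 2 gives 4100000 nM.
compound 3, `CN(C)C(=S)SC(=S)N1CCN(c2cccc(Cl)c2Cl)CC1`: in this assay compound 3 gives 1590000 nM.

Compound 2 carries the highest number of the three. Compound 1 sits within the scatter of it, so no order between those two is claimed; compound 3 lies beyond the scatter on the lower side. Compound 4, `CCSC(=S)N1CCN(C(=S)SC(=S)N(C)C)CC1`, differs from compound 2 by a group of 5 heavy atoms (3 carbon, 2 sulfur; no ring) in place of a group of 4 heavy atoms (4 carbon; no ring), on an amine nitrogen in a ring. For the measured compounds named here, no measured pair shows this change, so its size in this assay is open; a small move toward a lower number, likely within the scatter, is expected. Compound 4 is expected near 2500000 nM, range 800000 nM to 6000000 nM. The expected step is a 1.6-fold lower number from compound 2 to compound 4 (0.21 log units; within the scatter).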

Compound 4, half-maximal inhibitory concentration: 4480000 nM
Beside the measured number, compound 4's estimate is 1.8-fold (0.25 log units) below it, within the range that was stated.
By their numbers in this assay, from the lowest: compounds 3, 1, 2 and 4 (each within the scatter of the next, the first and the last beyond it).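

In this assay, the exchange of butyl for the group of 5 heavy atoms on the amine nitrogen in the ring gives a 1.1-fold higher number from compound 2 to compound 4 (0.04 log units; within the scatter), so the two compounds cannot be told apart. This position therefore accepts a group with 2 hydrogen-bond acceptors and a double bond outside aromatic rings in place of a plain butyl chain, with no separation in this read-out. On these data alone, whether a carboxylic acid, a primary amine or a chain longer than butyl at this nitrogen would give a step beyond the scatter remains open. No measurement shown here bears on the reason for this result.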